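The source may hold more compounds than are shown below. What is called first, only, known or untested is meant among the compounds shown, and "the series" means these compounds.

Measured so far: compound 2 `Oc1cccc(-c2cc(-c3ccccc3O)nc(-c3ccccc3O)c2)c1` gives 80 nM; compound 3 `Oc1ccccc1-c1cc(-c2ccccc2O)nc(-c2ccccc2O)c1` gives 140 nM; compound 1 `Oc1ccc(-c2cc(-c3cccc(O)c3)nc(-c3cccc(O)c3)c2)cc1` gives 730 nM, all in an ADME assay on HEK293 cells (Homo sapiens) for cytotoxicity, read by CCK-8 assay, with a stated time of 4 days; on this read-out higher numbers stand for weaker inhibition and lower numbers for stronger inhibition.

Compound 2 holds the lowest of the three numbers; compound 3 sits within the scatter of it, compound 1 stands beyond. Compound 4 `Oc1ccc(-c2cc(-c3cccc(O)c3)cc(-c3ccccc3O)n2)cc1` follows from compound 2 by 4-hydroxyphenyl in place of 2-hydroxyphenyl on an aromatic carbon. Among the compounds with values here, the one measured step between hydroxyphenyl isomers, a 1.8-fold higher number from compound 2 to compound 3 (0.24 log units; within the scatter), swaps 3-hydroxyphenyl for 2-hydroxyphenyl and stays within the scatter; no measured step places a 4-hydroxyphenyl alone. Within the data shown here, compound 1, the only measured compound carrying a 4-hydroxyphenyl, shows the highest number, but it differs from compound 2 in more than one place. For compound 4 a modest rise is therefore expected, a 2.5-fold higher number from compound 2 to compound 4 (0.40 log units; beyond the scatter). The estimate for compound 4 in this assay is 200 nM, between 80 nM and 600 nM.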

Compound 4, half-maximal inhibitory concentration: > 50000 nM
Compound 4 was reported as a limit; the forecaster's own chance of this, stated with the estimate: 5%; at least 250-fold (2.39 log units) between middle value and limit.
By their numbers in this assay, from the lowest: compounds 2 and 3 (each within the scatter of the next); then compound 1. At a limit, above all of these: compound 4.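

In this assay, 4-hydroxyphenyl in place of 2-hydroxyphenyl on the aromatic carbon next to the ring nitrogen gives an at least 620-fold higher number from compound 2 to compound 4 (2.79 log units; beyond the scatter), a large single-place change that the earlier step, a 1.8-fold higher number from compound 2 to compound 3 (0.24 log units; within the scatter), did not foreshadow. The placement of the hydroxyl on this one ring can thus decide the read-out, even with the atoms of the two compounds unchanged. Compound 4 is reported only as a limit, so the full size of the step stays undefined: the limit of > 50000 nM in this assay, at which 1 of the 4 values shown sits.

Still open, on these data alone, is how an amine or a methoxy group at this position would read. The compounds shown also leave open whether the hydroxyl at this position is itself required.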